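One Longer Side Chain, One Expected Binding Value

A few compounds are considered here, and "the series" means these few. Any claim that something is new, unique, unknown or untested is made for them only; others in the source may bear on it.

Compound 1 (`COCCNC(=O)c1cc2cccc(OC)c2oc1=N`) was tested in an assay on CHO cells for displacement of a labelled ligand from adenosine receptor A1 (Homo sapiens), read by scintillation counting, with a stated time of 60 min, tested at 10 uM; on this read-out higher numbers stand for more inhibition at the one concentration tested (going by the name of the read-out) and lower numbers for less inhibition. In this assay compound 1 gives > 70%, which is a limit of the measurement rather than a number, so compound 1 is known only to sit at that limit (the limit of > 70% in this assay, at which 1 of the 2 values shown sits). A second compound, compound 2 (`N=c1oc2ccc(Br)cc2cc1C(=O)NCCO`), was measured the same way; in this assay compound 2 gives 26%. Going by the values given here, compound 2 differs from compound 1 in more than one place, so these two values show only that compound 2 lies well under the limit reached by compound 1, and no single change can be read from them.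

Compound 3 (`COc1cccc2cc(C(=O)NCCCCCO)c(=N)oc12`) has not yet been measured. It differs from compound 1 in one place: 3-hydroxypropyl in place of methoxy on a saturated chain carbon, two bonds along the chain from an amide-type nitrogen. Among the compounds with values here, no measured step of this kind exists among the compounds here, so the size and direction of the change in this assay cannot be taken from the data; a step beyond the scatter in either direction is possible, and a downward shift is the expectation taken here. The expected step is a number at least 12 percentage points lower from compound 1 to compound 3 (beyond the scatter). Compound 3 is expected to give 58%, within 30% to 85%, before any measurement is known.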

Compound 3, a percentage reported as inhibition, at one concentration (the size of the read-out at that concentration, not a potency): 44%
Estimate against measurement, compound 3: 14 percentage points above, within the range that was stated.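

At this place, on a saturated chain carbon, two bonds along the chain from an amide-type nitrogen, the side chain can now be read as a single change, which the earlier pair could not offer. In this assay, putting 3-hydroxypropyl in place of methoxy gives a number at least 26 percentage points lower from compound 1 to compound 3 (beyond the scatter), so what this chain carries matters on this read-out, and here the longer chain with its hydroxyl goes with less inhibition at the one concentration tested. The exact size of the step stays unknown, because the value of compound 1 is a limit and not a number: the limit of > 70% in this assay, at which 1 of the 3 values shown sits.

The step changes the length of the chain and its end group together, so these compounds cannot say whether the length, the hydroxyl or both go with the lower value. On these data alone, how a plain pentyl chain, or a chain ending in an amine or a carboxylic acid, would read in this assay also stays open.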